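This account rests on a few compounds, and the source may have more. Where it says the series, first, only, none or still open, it means among the compounds named here.

Measured compounds and their values:
compound 1, `CNC(=O)c1cc(Oc2ccc3nc(NC(=O)Nc4cc(C(F)(F)F)cc(C(F)(F)F)c4)sc3c2)ccn1`: 96.3%
compound 2, `CNC(=O)c1cc(Oc2ccc3nc(NC(=O)c4ccc(Cl)cc4)sc3c2)ccn1`: 83%
compound 3, `CNC(=O)c1cc(Oc2ccc3nc(NC(=O)c4cc(C(F)(F)F)cc(C(F)(F)F)c4)sc3c2)ccn1`: 80.4%

All three were tested in a functional assay on SK-BR-3 cells (Homo sapiens) for inhibition, read by MTT assay, with a stated time of 2 days, tested at 100 uM; a higher number here means more inhibition of growth at the concentration tested, a lower number less inhibition of growth. Among these three numbers compound 2 stands second highest. Its nearest neighbour is compound 3, whose value lies within the scatter of that of compound 2, so the two cannot be told apart. Compound 1 lies furthest away, with a value beyond the scatter above that of compound 2.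

Compound 4, `CNC(=O)c1cc(Oc2ccc3nc(NC(=O)Nc4ccc(F)cc4)sc3c2)ccn1`, has not yet been measured. It differs from compound 2 in one place: (4-fluorophenyl)amino in place of 4-chlorophenyl on a carbonyl carbon. Cut one bond further out, the change reads (4-chlorophenyl)carbonyl to (4-fluorophenyl)carbamoyl. Among the compounds with values here, no step between measured compounds has been worked out, so the only guide is what two values show: compound 1 gives 96.3%, while compound 3 gives 80.4%. On that basis the step from compound 2 to compound 4 is expected to be upward, by a modest amount just beyond the scatter, a number 7 percentage points higher from compound 2 to compound 4 (within the scatter). Compound 4 is therefore estimated at 90%, with a range from 78% to 99%.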

Compound 4, percent growth inhibition at one concentration: 72.9%
Estimate against measurement, compound 4: 17.1 percentage points above, outside the stated range (below it).
By their numbers in this assay, from the lowest: compounds 4, 3 and 2 (each within the scatter of the next, the first and the last beyond it); then compound 1.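

On the carbonyl carbon, the change from 4-chlorophenyl to (4-fluorophenyl)amino gives in this assay a result of a number 10.1 percentage points lower from compound 2 to compound 4 (beyond the scatter). Adding an amino nitrogen at this place therefore does not always go with more inhibition of growth, even though compound 1 gives 96.3% while compound 3 gives 80.4%. The step also carries two differences at once, a new amino nitrogen with its hydrogen-bond donor and fluorine in place of chlorine on the ring, and nothing available explains the fall.

Which of the two differences goes with the lower number stays open, since neither (4-chlorophenyl)amino nor 4-fluorophenyl appears on this carbonyl carbon among the compounds shown. Also open, from the compounds shown here alone, is how a group without an aromatic ring, such as a simple alkyl amine, would behave at this place.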